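The source may hold more compounds than are shown below. What is called first, only, known or untested is meant among the compounds shown, and "the series" means these compounds.

Compound 3 `O=C1OCCN1C(=O)c1ccc(Oc2ccccc2)cc1` is one of three compounds examined in an assay on HEK293 cells for inhibition of N-acylethanolamine-hydrolyzing acid amidase (Rattus norvegicus), read by LC-MS, with a stated time of 30 min; a higher number here means a weaker inhibitor, a lower number a stronger inhibitor. Compound 3 gives 680 nM, the highest of the two numbers shown. Compound 1 `O=C(CCCCCc1ccc(F)c(Cl)c1)N1CCOC1=O` gives 26 nM in this assay. Compound 2 `O=C(CCCCCc1ccc(O)c(Cl)c1)N1CCOC1=O` gives only a limit of the assay, > 20000 nM. That reading for compound 2 is the limit of > 20000 nM in this assay, at which 1 of the 3 values shown sits. Among the measured compounds shown here, the one measured step, an at least 760-fold higher number from compound 1 to compound 2 (2.88 log units; beyond the scatter), concerns a hydroxy in place of a fluoro on the aromatic ring of compound 1; it does not touch the phenoxy group and so bears only loosely on compound 4 `CCC(CC)Oc1ccc(C(=O)N2CCOC2=O)cc1`, which differs from compound 3 in that (pentan-3-yl in place of phenyl on an oxygen on an aromatic ring). For the measured compounds named here, no measured step follows an alkyl in place of an aryl group on that oxygen, so the expectation rests on compound 3 alone. Compound 4 is therefore expected to give a number close to that of compound 3 in this assay, with a modest move toward a higher number allowed, a 2.2-fold higher number from compound 3 to compound 4 (0.34 log units; beyond the scatter). Compound 4 is estimated at 1500 nM, within a range from 300 nM to 8000 nM.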

Compound 4, half-maximal inhibitory concentration: 480 nM
Beside the measured number, compound 4's estimate is 3.1-fold (0.49 log units) above it, and the stated range covers the measured number.
By their numbers in this assay, from the lowest: compound 1; then compounds 4 and 3 (each within the scatter of the next). At a limit, above all of these: compound 2.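

In this assay, exchanging phenyl for pentan-3-yl on an oxygen on an aromatic ring gives a 1.4-fold lower number from compound 3 to compound 4 (0.15 log units; within the scatter), so the two groups cannot be told apart at this position, even though one is an aromatic ring and the other has no ring. Among the compounds shown here, the only earlier step, an at least 760-fold higher number from compound 1 to compound 2 (2.88 log units; beyond the scatter), lay in another place on a different core and could not show that this position accepts such an exchange with no change beyond the scatter. No information given here bears on why the two groups give such similar numbers.

As far as these compounds go, it remains open whether a methyl group, a cyclohexyl ring or a longer chain on that oxygen would also stay within the scatter of these two compounds. From the compounds shown here alone, it is equally open whether an amine or a carboxylic acid carried on that group would be tolerated.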